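Methoxy for methylsulfanyl on a quinazoline-type cytotoxicity series

A few compounds are considered here, and "the series" means these few. Any claim that something is new, unique, unknown or untested is made for them only; others in the source may bear on it.

Three compounds were measured in a functional assay on CCRF-CEM cells (Homo sapiens) for cytotoxicity, read by MTT assay, with a stated time of 72 h; on this read-out lower numbers stand for stronger inhibition of growth and higher numbers for weaker inhibition of growth.

compound 1 `CSc1ccc(CNc2nc(SC)nc3ncccc23)cc1`: 5350 nM
compound 2 `COc1ccc(CNc2nc([SeH])nc3ccccc23)cc1`: > 100000 nM, a limit of the assay
compound 3 `CSc1ccc(CNc2nc([SeH])nc3ccccc23)cc1`: 71900 nM

Compound 1 gives the lowest of the two numbers; compound 3 gives a higher number, and the gap is beyond the usual scatter. The difference between the two cores is not broken down here. From compound 3 to compound 2 the change is methoxy in place of methylsulfanyl on an aromatic carbon, and the step is an at least 1.3-fold higher number from compound 3 to compound 2 (0.14 log units; that floor lies within the scatter). For compound 2 only a limit is known, (the limit of > 100000 nM in this assay, at which 1 of the 3 values shown sits).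

Compound 4 `COc1ccc(CNc2nc(SC)nc3ncccc23)cc1` is not yet measured. It differs from compound 1 by methoxy in place of methylsulfanyl on an aromatic carbon, the same change as from compound 3 to compound 2. Resting on an at least 1.3-fold higher number from compound 3 to compound 2 (0.14 log units; that floor lies within the scatter), a weakening step is expected from compound 1 to compound 4, estimated at a 2.1-fold higher number from compound 1 to compound 4 (0.31 log units; beyond the scatter). Compound 4 is therefore estimated at 11000 nM, between 4000 nM and 40000 nM.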

Compound 4, concentration for 50% growth inhibition: > 100000 nM
Compound 4: only a limit was reported (the forecaster's own chance of this, stated with the estimate: 10%); middle value at least 9.0-fold (0.95 log units) from the limit.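

In this assay, methoxy in place of methylsulfanyl on an aromatic carbon gives an at least 18-fold higher number from compound 1 to compound 4 (1.27 log units; beyond the scatter), a large step on the core of compound 1. The value of compound 4, > 100000 nM, is a limit of the assay. The change thus also leads to a higher number on this core, but whether its size matches that on the core of compound 3 is not shown: the same change on two cores in this assay, an at least 1.3-fold higher number (0.14 log units; that floor lies within the scatter) from compound 3 to compound 2 and an at least 18-fold higher number (1.27 log units; beyond the scatter) from compound 1 to compound 4; the limit leaves it open whether they differ

The compounds shown leave open what an amine, a longer chain such as ethoxy, or a chlorine atom would do on the same aromatic carbon. The true size of the methoxy step also stays open on both cores, as compound 2 and compound 4 rest at the same limit: the limit of > 100000 nM in this assay, at which 2 of the 4 values shown sit.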